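A few compounds are considered here, and "the series" means these few. Any claim that something is new, unique, unknown or untested is made for them only; others in the source may bear on it.

Measured compounds in the series:

Compound 1, `COc1cc(-c2nn(-c3cccc(NC(=O)Nc4ccc(Cl)c(Cl)c4)c3)cc2-c2ccncc2)ccc1Cl`: in a functional assay on OVCAR-5 cells (Homo sapiens) for inhibition, read by sulforhodamine B assay, with a stated time of 48 h (a higher number here means a weaker inhibitor of growth, a lower number a stronger inhibitor of growth), compound 1 gives > 50000 nM, which is a limit of the assay and not a number.

Compound 2, `O=C(Nc1cccc(-n2cc(-c3ccncc3)c(-c3ccc(Cl)c(O)c3)n2)c1)Nc1ccc(Cl)c(Cl)c1`: in this assay compound 2 gives > 32500 nM, again a limit of the assay and not a number.

Compound 2 therefore stands at a limit only. Both values shown sit at limits, the limit of > 32500 nM in this assay, at which 1 of the 2 values shown sits, and (the limit of > 50000 nM in this assay, at which 1 of the 2 values shown sits), so the step that the two limits leave unreadable from compound 1 to compound 2 cannot be read in either direction or size. No numbered value exists in this assay for any compound in the series.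

Compound 3, `O=C(Nc1cccc(-n2cc(-c3ccncc3)c(-c3ccc(Cl)c(O)c3)n2)c1)Nc1ccc(Cl)c(C(F)(F)F)c1`, is not yet measured. It differs from compound 2 by trifluoromethyl in place of chloro on an aromatic carbon. Within the data shown here, no measured step touches this position: the only recorded step is the one from compound 1 to compound 2, which changes a different group and is itself unreadable. There is thus nothing in the data to suggest a step beyond the scatter, and with compound 2 at a limit, compound 3 is expected to return a limit as well. Among the measured compounds shown here, the step that the limit leaves unreadable from compound 2 to compound 3 is estimated to be no step at all beyond the scatter. Compound 3 is therefore expected at 40000 nM, with a range of 12000 nM to 100000 nM, most probably reported only as a limit.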

Compound 3, concentration for total growth inhibition: 16200 nM
For compound 3 the middle estimate is 2.5-fold (0.39 log units) above the measured one, within the range that was stated.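

In this assay, among these compounds, compound 3 gives 16200 nM, the first numbered value, so this site on the aromatic ring, ortho to a chloro group, now has a readout that is not a limit, with the (3,4-dichlorophenyl)amino group exchanged for (4-chloro-3-(trifluoromethyl)phenyl)amino. Trifluoromethyl in place of chloro reads as an at least 2.0-fold lower number from compound 2 to compound 3 (0.30 log units; that floor lies within the scatter), so the direction is toward a lower number, but the floor of that step does not by itself establish a change beyond the scatter. The step has only a floor and no full size because compound 2 stands at a limit and not at a number: the limit of > 32500 nM in this assay, at which 1 of the 3 values shown sits.

As far as these compounds go, the true size of the step remains open, and the step with hydrogen in place of methyl on the oxygen cannot be read, so it is unknown how that oxygen substituent behaves alongside trifluoromethyl. Also open, from the compounds shown here alone, is whether this site tolerates other replacements for chloro, such as a nitrile, a methyl or an amine, and whether any of them would reach a lower number than compound 3.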